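The compounds below may be only part of what the source reports. "The series", "measured", "known", "first", "only" and "open" are said of these compounds alone.

Measured so far:
- compound 1 `O=C(Oc1ccc(OCc2ccccc2)cc1)N(Cc1ccccc1)S(=O)(=O)c1ccc(Cl)cc1`: 44.1%
- compound 2 `O=C(Nc1ccc(OCCCCc2ccccc2)cc1)N(Cc1ccccc1)S(=O)(=O)c1ccc(Cl)cc1`: 74.5%

In an ADME assay on microsomes from liver (Rattus norvegicus) for metabolic stability, read by LC-MS, using NADPH, with a stated time of 30 min, tested at 1 uM (on this read-out higher numbers stand for a more stable compound and lower numbers for a less stable compound), compound 1 gives 44.1%, the lower of the two numbers, and compound 2 lies beyond the usual scatter above it. Compound 3 `O=C(Oc1ccc(OCc2ccccc2)cc1)N(Nc1ccccc1)S(=O)(=O)c1ccc(Cl)cc1` keeps the core of compound 1 but carries anilino in place of benzyl on an amide-type nitrogen. Among the measured compounds shown here, no measured pair differs in only one place, so nothing here directly shows the size of such a step. The expected step of a number 2.1 percentage points lower from compound 1 to compound 3 (within the scatter) is small, within the scatter, though this is uncertain. For compound 3 the estimated value is 42%, with an expected range from 18% to 68%.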

Compound 3, percent of the compound remaining: 16.3%
Estimate against measurement, compound 3: 25.7 percentage points above; measured number outside the range, below it.
By their numbers in this assay, from the lowest: compound 3; then compound 1; then compound 2.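

Placing anilino in place of benzyl on an amide-type nitrogen, in this assay, gives a number 27.8 percentage points lower from compound 1 to compound 3 (beyond the scatter). This position is therefore sensitive to the change, even though both groups carry one six-membered aromatic ring of carbon only; the entering group adds a nitrogen, a hydrogen-bond donor and a hydrogen-bond acceptor. Nothing measured here explains the step. Still open, on these data alone, is how a small methyl or a saturated cyclohexyl group on this nitrogen would compare, and whether anilino would give a similar step on the core of compound 2.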